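Removing the aryl ketone arm in a weakly cytotoxic series

The compounds below may be only part of what the source reports. "The series", "measured", "known", "first", "only" and "open" are said of these compounds alone.

compound 1 `Cc1ccc(C(=O)CSc2nnc(C)n2N2C(=O)c3ccccc3C2=O)cc1`: > 200000 nM
compound 2 `CSc1nnc(C)n1N1C(=O)c2ccccc2C1=O`: > 200000 nM
compound 3 `CCc1nnc(SCC(=O)c2ccc(C)cc2)n1N1C(=O)c2ccccc2C1=O`: > 200000 nM

All three were tested in a functional assay on PC-3M cells (Homo sapiens) for cytotoxicity, read by MTT assay, with a stated time of 48 h; a higher number here means a weaker inhibitor, a lower number a stronger inhibitor. For compound 1 the value is a limit of the assay, not a number. The same holds for compound 2. Compound 3 likewise sits at a limit. The change from compound 1 to compound 2 is hydrogen in place of (4-methylphenyl)carbonyl on a saturated chain carbon bound to a sulfur; its step, a step that the two limits leave unreadable from compound 1 to compound 2, stays unreadable because of the limit of > 200000 nM in this assay, at which 3 of the 3 values shown sit. The two cores differ by methyl in place of hydrogen on a saturated chain carbon bound to an aromatic carbon, and that step, a step that the two limits leave unreadable from compound 1 to compound 3, is equally hidden by the limits.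

Compound 4 `CCc1nnc(SC)n1N1C(=O)c2ccccc2C1=O` has not been measured. It differs from compound 3 by hydrogen in place of (4-methylphenyl)carbonyl on a saturated chain carbon bound to a sulfur, the same change as from compound 1 to compound 2, at the same place. Since compound 3 already rests at a limit, > 200000 nM, the step of a number no higher from compound 3 to compound 4 (the limit leaves the size open) is expected to be flat. Compound 4 is expected to give about 200000 nM, most likely reported again as a limit, within 100000 nM to 300000 nM.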

Compound 4, half-maximal inhibitory concentration: > 200000 nM
Compound 4: no number, only a limit; the forecaster's own chance of this, stated with the estimate: 90%; the middle value lies on the limit itself.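

Neither the step to compound 4 from compound 3 nor the one from compound 2 can be read, because every result is a limit, not a number: the limit of > 200000 nM in this assay, at which 4 of the 4 values shown sit.

The compounds shown leave open whether the (4-methylphenyl)carbonyl group or the added methyl changes cytotoxicity at all.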